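Saturating the ring attached to the chain carbon of compound 3

The source may report more compounds than this note shows. Statements on the series, on what has been measured and on what is new or still open speak of the compounds shown alone.

Compound 1 `Nc1nc(-c2ccco2)nc2sc(CN3CC=CC3)cc12`: 290 nM
Compound 2 `Nc1nc(-c2ccc(Br)o2)nc2sc(CN3CCCC3)cc12`: 710 nM
Compound 3 `N#Cc1cccc(-c2nc(N)c3cc(CN4CC=CC4)sc3n2)c1`: 2070 nM

In an assay on CHO-K1 cells for antagonist activity at adenosine receptor A1 (Homo sapiens), read by a beta-galactosidase reporter, with stated times of 15 min and 6 h (a lower number here means a stronger inhibitor, a higher number a weaker inhibitor), compound 3 gives 2070 nM, the highest of the three numbers; compound 2 stands nearest, compound 1 furthest. Compound 4 `N#Cc1cccc(-c2nc(N)c3cc(CN4CCCC4)sc3n2)c1` differs from compound 3 in one place: a group of 5 heavy atoms (4 carbon, 1 nitrogen; one five-membered non-aromatic ring with 1 hetero atom) in place of a group of 5 heavy atoms (4 carbon, 1 nitrogen; one five-membered non-aromatic ring with 1 hetero atom), on a saturated chain carbon bound to an aromatic carbon. Among the compounds with values here, the only measured single-change step, a 7.1-fold higher number from compound 1 to compound 3 (0.85 log units; beyond the scatter), concerns the aromatic substituent and not the saturated ring, so it does not bear on this change. Compound 2 also carries pyrrolidin-1-yl, but it is not a single-change partner of any other compound, and it gives 710 nM; nothing more can be drawn from it. Within the data shown here, with no step that speaks to this exchange, compound 4 is expected to sit close to compound 3, with a 1.0-fold lower number from compound 3 to compound 4 (0.01 log units; within the scatter) not beyond the scatter. Compound 4 is therefore estimated at 2000 nM in this assay, within the range 800 nM to 5000 nM.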

Compound 4, inhibition constant: 130 nM
Compound 4: the middle estimate sits 15-fold (1.19 log units) above what was measured; measured number below the stated range.
By their numbers in this assay, from the lowest: compound 4; then compound 1; then compound 2; then compound 3.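

In this assay, within the data shown here, the only change on a saturated chain carbon bound to an aromatic carbon, pyrrolidin-1-yl for a ring of the same size that carries a double bond, gives the largest step (a 16-fold lower number from compound 3 to compound 4 (1.20 log units; beyond the scatter)), so this position matters at least as much as the aromatic substituent, which was the only place a step had been read before. With pyrrolidin-1-yl in place, 3-cyanophenyl instead of 5-bromofuran-2-yl also lowers the number (a 5.5-fold lower number from compound 2 to compound 4 (0.74 log units; beyond the scatter)), whereas with the unsaturated ring 3-cyanophenyl instead of furan-2-yl raised it (a 7.1-fold higher number from compound 1 to compound 3 (0.85 log units; beyond the scatter)), although the two groups replaced are not the same. No measurement here explains either result.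

The compounds shown leave open whether a piperidin-1-yl or morpholin-4-yl ring, or an open-chain amine such as diethylamino, would hold this position as well. They also leave open whether pyrrolidin-1-yl would lower the number alongside furan-2-yl as it does alongside 3-cyanophenyl.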